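Inserting an ether oxygen into the triazole side chain

The source may report more compounds than this note shows. Statements on the series, on what has been measured and on what is new or still open speak of the compounds shown alone.

Measured compounds:
- compound 1 `CCCCc1cn(CCNc2nonc2/C(=N/O)Nc2ccc(F)c(Br)c2)nn1`: 830 nM
- compound 2 `OCCCc1cn(CCNc2nonc2/C(=N/O)Nc2ccc(F)c(Br)c2)nn1`: 958 nM
- compound 3 `CC(C)CC(C)(O)c1cn(CCNc2nonc2/C(=N/O)Nc2ccc(F)c(Br)c2)nn1`: 689 nM

In an assay on isolated protein for inhibition of Indoleamine 2,3-dioxygenase 2 (Homo sapiens) (a lower number here means a stronger inhibitor, a higher number a weaker inhibitor), compound 2 gives 958 nM, the highest of the three numbers, yet it is separated from its two neighbours only by a 1.2-fold higher number from compound 1 to compound 2 (0.06 log units; within the scatter) and by a 1.4-fold lower number from compound 2 to compound 3 (0.14 log units; within the scatter), so none of the three compounds is separated from the others beyond the scatter. Compound 4 `OCCOCc1cn(CCNc2nonc2/C(=N/O)Nc2ccc(F)c(Br)c2)nn1` has not been measured. It differs from compound 2 in one place: 2-hydroxyethoxy in place of 2-hydroxyethyl on a saturated chain carbon bound to an aromatic carbon. The three measured steps all concern the same side chain on the shared core and all stayed within the scatter, including a 1.2-fold lower number from compound 1 to compound 3 (0.08 log units; within the scatter), where 1-hydroxy-1,3-dimethylbutyl entered in place of butyl. Among the compounds with values here, nothing among the measured compounds suggests that the side chain shifts this assay much, so compound 4 is expected to show a step of a 1.1-fold lower number from compound 2 to compound 4 (0.03 log units; within the scatter), no larger than the scatter. The estimate for compound 4 in this assay is therefore 900 nM, within a range of 450 nM to 1800 nM.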

Compound 4, half-maximal inhibitory concentration: 144 nM
For compound 4 the middle estimate is 6.3-fold (0.80 log units) above the measured one; measured number outside the range, below it.
By their numbers in this assay, from the lowest: compound 4; then compounds 3, 1 and 2 (each within the scatter of the next).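

In this assay, within the data shown here, the side chain on the shared core now proves able to move the number: (2-hydroxyethoxy)methyl in place of 3-hydroxypropyl gives a 6.7-fold lower number from compound 2 to compound 4 (0.82 log units; beyond the scatter), the first step at this position beyond the scatter. The comparisons with the other two chains agree, with a 5.8-fold lower number from compound 1 to compound 4 (0.76 log units; beyond the scatter) and a 4.8-fold lower number from compound 3 to compound 4 (0.68 log units; beyond the scatter), so compound 4 stands apart from three compounds that remain within the scatter of one another. Hydroxy alone does not set compound 4 apart, since compound 2 and compound 3 also carry one, but no measurement here explains why the chain with the ether oxygen behaves differently.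

Still open, from the compounds shown here alone, is whether the ether oxygen needs the hydroxy, which a methoxy in its place would test. An amine in place of the ether oxygen, or a longer chain with a second ethoxy unit, could also show how far this gain extends.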